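Trifluoromethyl for 4-(trifluoromethoxy)phenoxy: notes on compound 4

The compounds below may be only part of what the source reports. "The series", "measured", "known", "first", "only" and "open" are said of these compounds alone.

Measured in an ADME assay on J774 cells (Mus musculus) for antiproliferative activity, with a stated time of 72 h; a lower number here means that less compound is needed, a higher number that more compound is needed for the effect:
Compound 1 `CCCCc1cc2c(=O)cc(C)[nH]c2cc1OCCOc1ccccc1` gives 28000 nM
Compound 2 `CCCCc1cc2c(=O)c(-c3ccncc3)c(C)[nH]c2cc1OCCOc1ccccc1` gives 23000 nM
Compound 3 `CCCCc1cc2c(=O)c(-c3ccc(Oc4ccc(OC(F)(F)F)cc4)cc3C)c(C)[nH]c2cc1OCCOc1ccccc1` gives 16000 nM

The three values are not separated: compound 3 (16000 nM) lies within the scatter of both compound 1 and compound 2. Within the data shown here, the only measured step with a single change is a 1.2-fold lower number from compound 1 to compound 2 (0.09 log units; within the scatter) and it does not leave the scatter. Compound 1 lacks the aromatic substituent that compound 2 and compound 3 carry, yet all three values remain close in this assay across these different substituents.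

Compound 4 `CCCCc1cc2c(=O)c(-c3ccc(C(F)(F)F)cc3C)c(C)[nH]c2cc1OCCOc1ccccc1` is the next to be measured. It differs from compound 3 by trifluoromethyl in place of 4-(trifluoromethoxy)phenoxy on an aromatic carbon. Among the measured compounds shown here, no measured step tests this exchange directly, so the expectation rests on compound 3 (16000 nM) and on the small size of a 1.2-fold lower number from compound 1 to compound 2 (0.09 log units; within the scatter) in this short series. No firm direction can be drawn from these data, and a shift no larger than the scatter is expected (a 1.3-fold higher number from compound 3 to compound 4 (0.10 log units; within the scatter)). For compound 4 the estimate is 20000 nM with an expected range from 10000 nM to 38000 nM in this measure.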

Compound 4, half-maximal effective concentration: 20000 nM
Compound 4: the middle estimate sits on the measured number at the digits printed; the measured number falls inside the stated range.
By their numbers in this assay, from the lowest: compounds 3, 4, 2 and 1 (each within the scatter of the next).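

At the place para to a large group and meta to a methyl group, this assay now gives a direct reading of one exchange: 4-(trifluoromethoxy)phenoxy, with 12 heavy atoms and an aromatic ring, gives way to trifluoromethyl, with 4 heavy atoms and no ring (a 1.3-fold higher number from compound 3 to compound 4 (0.10 log units; within the scatter)). Among these compounds, removing that ring and both oxygen atoms therefore leaves the number within the scatter, which no earlier step could show. At the aromatic carbon of the shared core, 2-methyl-4-(trifluoromethyl)phenyl is also not separated from pyridin-4-yl (a 1.2-fold lower number from compound 2 to compound 4 (0.06 log units; within the scatter)) or from hydrogen (a 1.4-fold lower number from compound 1 to compound 4 (0.15 log units; within the scatter)), so all four compounds remain unresolved, and no measurement available here accounts for this.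

Still open, as far as these compounds go, is whether any group at the place of the trifluoromethyl, such as a primary amine or a carboxylic acid, would move the number beyond the scatter. From the compounds shown here alone, the butyl chain and the 2-phenoxyethoxy group are the same in all four compounds, so the effect of replacing the butyl with a hydroxyl or a longer chain also remains unknown.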